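Lengthening the linker and moving the halogen in benzylamine sulfonamides

This account rests on a few compounds, and the source may have more. Where it says the series, first, only, none or still open, it means among the compounds named here.

Measured compounds:
compound 1, `O=S(=O)(NCCCNCc1ccccc1Cl)c1cc(C(F)(F)F)cc(C(F)(F)F)c1`, 13000 nM
compound 2, `CC(C)(C)c1ccc(CNCCCNS(=O)(=O)c2cc(C(F)(F)F)cc(C(F)(F)F)c2)cc1`, 2700 nM
compound 3, `O=S(=O)(NCCNCc1ccc(-c2ccccc2)cc1)c1cc(C(F)(F)F)cc(C(F)(F)F)c1`, 2800 nM

In a functional assay on ASPC1 cells (Homo sapiens) for inhibition, read by MTT assay, with a stated time of 72 h (on this read-out lower numbers stand for stronger inhibition of growth and higher numbers for weaker inhibition of growth), compound 1 stands highest of the three numbers; compound 3 sits beyond the scatter below it, and compound 2 likewise. The change to compound 4, `O=S(=O)(NCCCCNCc1ccc(Br)cc1)c1cc(C(F)(F)F)cc(C(F)(F)F)c1`, is ((4-bromobenzyl)amino)methyl in place of (2-chlorobenzyl)amino on a saturated chain carbon, three bonds along the chain from a sulfonamide nitrogen, so both the benzyl substituent and the chain between the two nitrogens are altered at once. Going by the values given here, the one step that bears on it is a 4.8-fold lower number from compound 1 to compound 2 (0.68 log units; beyond the scatter), where a different 4-substituted benzyl group replaced the same 2-chlorobenzyl group. Among the compounds with values here, compound 3 with its shorter chain gives 2800 nM, but no pair isolates the chain change itself. The step is therefore expected to be a lowering of modest size, a 2.9-fold lower number from compound 1 to compound 4 (0.46 log units; beyond the scatter). Compound 4 is estimated at 4500 nM, in the range 1500 nM to 13000 nM.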

Compound 4, concentration for 50% growth inhibition: 2900 nM
Estimate against measurement, compound 4: 1.6-fold (0.19 log units) above; low and high end bracket the measured number.
By their numbers in this assay, from the lowest: compounds 2, 3 and 4 (each within the scatter of the next); then compound 1.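

In this assay, the replacement of (2-chlorobenzyl)amino by ((4-bromobenzyl)amino)methyl gives a 4.5-fold lower number from compound 1 to compound 4 (0.65 log units; beyond the scatter). A second departure from the (2-chlorobenzyl)amino group of compound 1 thus lowers the number beyond the scatter, as a 4.8-fold lower number from compound 1 to compound 2 (0.68 log units; beyond the scatter) did, this time with a change that also adds to the chain. Nothing available explains this lowering.

The step changes the halogen and the chain together, so their separate shares cannot be read. As far as these compounds go, what a longer chain, or a methoxy group in place of the bromine, would give remains open.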